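The compounds below may be only part of what the source reports. "The series", "measured", "known", "first", "only" and "open" are said of these compounds alone.

Compound 1 `CN(C)C(=O)c1cc2cnc(Nc3ccc(S(=O)(=O)NCCCCCN=C=S)cc3)nc2n1C1CCCC1`: in a functional assay on A549 cells (Homo sapiens) for inhibition, read by CCK-8 assay, with a stated time of 72 h, tested at 1 uM (a higher number here means a stronger effect of the compound at the concentration tested, a lower number a weaker effect), compound 1 gives 56.6%.
Compound 2 `CN(C)C(=O)c1cc2cnc(Nc3ccc(C(=O)NCCCCN=C=S)cc3)nc2n1C1CCCC1`: in this assay compound 2 gives 30.2%.

Within the data shown here, of the two measured compounds, compound 2 stands lowest, with 30.2% in this assay, and the only step recorded, a number 26.4 percentage points lower from compound 1 to compound 2 (beyond the scatter), leaves it clearly under compound 1. Compound 3 `CN(C)C(=O)c1cc2cnc(Nc3ccc(NC(=O)CCCN=C=S)cc3)nc2n1C1CCCC1` has not yet been tested. It differs from compound 2 in one place, (a group of 9 heavy atoms (5 carbon, 2 nitrogen, 1 oxygen, 1 sulfur; no ring) in place of a group of 10 heavy atoms (6 carbon, 2 nitrogen, 1 oxygen, 1 sulfur; no ring), on an aromatic carbon), so the chain on the aromatic carbon is again rebuilt, now with one heavy atom fewer. Among the measured compounds shown here, the single step available bears on this change only loosely: it shows that swapping the group at this same aromatic carbon moved the number by a modest amount, and in the downward direction. For the measured compounds named here, no measured pair shows a reversed amide or a shortened chain, so the direction for compound 3 is open. The change is expected to move the number by little, with a step of a number 0.2 percentage points lower from compound 2 to compound 3 (within the scatter), leaving compound 3 near compound 2. Compound 3 is therefore estimated at 30% in this assay, within a range of 12% to 50%.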

Compound 3, a percentage reported as inhibition, at one concentration (the size of the read-out at that concentration, not a potency): 56.1%
Compound 3: the middle estimate sits 26.1 percentage points below what was measured, outside the stated range (above it).
By their numbers in this assay, from the lowest: compound 2; then compounds 3 and 1 (each within the scatter of the next).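

In this assay, this position, on an aromatic carbon para to a large group, proves sensitive even to a small exchange: putting the group of 9 heavy atoms in place of the group of 10 heavy atoms gives a number 25.9 percentage points higher from compound 2 to compound 3 (beyond the scatter), although both groups carry the same counts of hydrogen-bond donors and acceptors and neither has a net charge. Group size does not order the results, since the group of 12 heavy atoms and the group of 9 heavy atoms read alike, with a number 0.5 percentage points lower from compound 1 to compound 3 (within the scatter), while the group of 10 heavy atoms, intermediate in size, gives the lowest number of the three, beyond the scatter of both others. Nothing available explains why these groups differ in this way.

In each step the way the chain is joined to the ring and the length of the chain change together, so the compounds shown cannot separate the contribution of either one. Going by these compounds, it also remains open whether a longer chain joined as in compound 3, or an amine in place of the isothiocyanate at the chain end, would keep the number close to that of compound 3.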